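The compounds below may be only part of what the source reports. "The series", "measured", "known", "first", "only" and "open" are said of these compounds alone.

Working notes on the series, all values from an ADME assay on MDBK cells (Bos taurus) for cytotoxicity; on this read-out higher numbers stand for lower toxicity in this test and lower numbers for higher toxicity in this test:
- compound 1 `Cc1ccc(Cn2ccc3nc(-c4ccccc4)nc-3c2)cc1` gives > 100000 nM (a limit)
- compound 2 `Fc1ccccc1Cn1ccc2nc(-c3ccccc3)nc-2c1` gives > 100000 nM (a limit)
- compound 3 `Fc1cccc(Cn2ccc3nc(-c4ccccc4)nc-3c2)c1` gives > 100000 nM (a limit)

Compound 1 gives > 100000 nM, which is a limit and not a number. It has no ranking within the series, which so far shows only (the limit of > 100000 nM in this assay, at which 3 of the 3 values shown sit).

The change to compound 4 `FC(F)(F)c1ccc(Cn2ccc3nc(-c4ccccc4)nc-3c2)cc1` is trifluoromethyl in place of methyl on an aromatic carbon, para to a large group: trifluoromethyl in place of methyl on an aromatic carbon.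

Among the measured compounds shown here, three measured steps bear on this change, all on the same aromatic group: a step that the two limits leave unreadable from compound 1 to compound 2, a step that the two limits leave unreadable from compound 1 to compound 3 and a step that the two limits leave unreadable from compound 2 to compound 3. None of them has a readable size, so they supply no direction. No step beyond the scatter is expected in this assay, and compound 4 will most likely be reported as a limit again.

The expected step is a number no higher from compound 1 to compound 4 (the limit leaves the size open).

For compound 4 the estimated value is 100000 nM, with an expected range from 50000 nM to 200000 nM.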

Compound 4, half-maximal cytotoxic concentration: 84000 nM
Compound 4: middle estimate off by 1.2-fold (0.08 log units), on the high side; measured number inside the range.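

Notes on this assay: trifluoromethyl in place of methyl on an aromatic carbon, para to a large group, gives the first step in the series with a readable direction, an at least 1.1-fold lower number from compound 1 to compound 4 (0.07 log units; that floor lies within the scatter). The steps among compound 1, compound 2 and compound 3 cannot be read, and compound 4 is the first compound here with a number rather than a limit, while the rest of the series stays at one: the limit of > 100000 nM in this assay, at which 3 of the 4 values shown sit. The floor of the new step lies within the scatter, so this change is not shown to lower the number by more than the scatter allows.

Going by these compounds, the true size of the step stays open, as the value of compound 1 is a limit. Also open, on these data alone, is what an amine or a carboxylic acid would give in place of trifluoromethyl on the same aromatic carbon.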